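This account rests on a few compounds, and the source may have more. Where it says the series, first, only, none or still open, it means among the compounds named here.

Compound 1 `COc1cc(N)c(Cl)cc1NC(=O)C1CCN(Cc2ccccc2Cl)CC1`, compound 2 `CCCCCN1CCC(C(=O)Nc2cc(Cl)c(N)cc2OC)CC1` and compound 3 `COc1cc(N)c(Cl)cc1NC(=O)C1CCN(Cc2ccc(O)cc2)CC1` share one core and differ only in the group on a saturated chain carbon bound to an amine nitrogen in a ring. In a functional assay on the whole organism for antagonist activity, with Mus musculus as the target (on this read-out lower numbers stand for an effect already at smaller amounts and higher numbers for an effect only at larger amounts of compound), compound 1 reaches only a limit, > 4 mg/kg. For compound 2 the read-out in this assay is likewise a limit, > 10 mg/kg. Compound 3 also gives a limit in this assay, > 8 mg/kg. Compound 3 thus stands on a limit, and the two other values around it are limits as well (the limit of > 10 mg/kg in this assay, at which 1 of the 3 values shown sits, (the limit of > 4 mg/kg in this assay, at which 1 of the 3 values shown sits), (the limit of > 8 mg/kg in this assay, at which 1 of the 3 values shown sits)). The steps a step that the two limits leave unreadable from compound 1 to compound 2, a step that the two limits leave unreadable from compound 1 to compound 3 and a step that the two limits leave unreadable from compound 2 to compound 3 are therefore all unreadable in size. Compound 4 `COc1cc(N)c(Cl)cc1NC(=O)C1CCN(Cc2ccccc2F)CC1` differs from compound 3 by 2-fluorophenyl in place of 4-hydroxyphenyl on a saturated chain carbon bound to an amine nitrogen in a ring. The steps a step that the two limits leave unreadable from compound 1 to compound 3 and a step that the two limits leave unreadable from compound 2 to compound 3 touch the same place yet give no readable size, so no direction in this assay can be drawn from them. On that basis compound 4 is expected to give 8 mg/kg, with a range from 2 mg/kg to 30 mg/kg. The step of a number no higher from compound 3 to compound 4 (the limit leaves the size open) is thus estimated as one not readable beyond the scatter, and a limit remains likely.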

Compound 4, dose for half-maximal effect: > 4 mg/kg
Compound 4: no number, only a limit (the forecaster's own chance of this, stated with the estimate: 70%); the middle value does not contradict the limit.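

Going by these compounds alone, compound 4 gives only a limit, > 4 mg/kg, so no step between compound 4 and compound 1, compound 2 or compound 3 can be read. The compounds shown leave open how the group on a saturated chain carbon bound to an amine nitrogen in a ring changes the effective dose in this assay.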